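The source may report more compounds than this note shows. Statements on the series, on what has been measured and on what is new or still open speak of the compounds shown alone.

Compound 1, `COc1cccc(Cn2cnc3c(N(C)C)ncnc32)c1`: 48% in a functional assay on the whole organism for inhibition, with Rattus norvegicus as the target, at a dose of 25 mg/kg by the intraperitoneal route; a lower number here means less inhibition, a higher number more inhibition at the dose given (going by the name of the read-out)
Compound 2, `CN(C)c1ncnc2c1ncn2C1CCCCCC1`: 0%
Compound 3, `c1nc(N2CCC2)c2ncn(CC3CC3)c2n1`: 30%

Among these three numbers compound 3 stands second highest in this assay. Compound 1 sits above it by a gap beyond the usual scatter, and compound 2 sits below it, also beyond the scatter. Compound 4, `c1nc(NCC2CC2)c2ncn(CC3CC3)c2n1`, differs from compound 3 in a single place: (cyclopropylmethyl)amino in place of azetidin-1-yl on an aromatic carbon. Within the data shown here, no pair of measured compounds differing in only one place is available, so no step of known size serves as a guide here. In this assay the expected step is no change at the digits printed from compound 3 to compound 4 (within the scatter), not beyond the scatter in either direction. Compound 4 is accordingly estimated at 30%, with a range from 10% to 55%.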

Compound 4, a percentage reported as inhibition, in the whole organism at one dose (the size of the read-out at that dose, not a potency): 28%
Beside the measured number, compound 4's estimate is 2 percentage points above it, within the range that was stated.
By their numbers in this assay, from the lowest: compound 2; then compounds 4 and 3 (each within the scatter of the next); then compound 1.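

Among these compounds, putting (cyclopropylmethyl)amino in place of azetidin-1-yl on an aromatic carbon gives the only single-place step available in this assay, a number 2 percentage points lower from compound 3 to compound 4 (within the scatter), and it is the first direct reading at this position. The four-membered ring leaves and a hydrogen-bond donor enters, with no shift beyond the scatter in this read-out. No evidence at hand accounts for this result. From the compounds shown here alone, it remains open whether a morpholine ring, a primary amine or a longer alkyl chain at this position would hold the number or shift it.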